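The compounds below may be only part of what the source reports. "The series", "measured", "known", "first", "only" and "open" are said of these compounds alone.

Compound 2 `O=C(O)c1cc(-c2ncco2)ccc1O` is measured in a functional assay on the whole organism for inhibition, with Rattus norvegicus as the target, read by paw edema (on this read-out higher numbers stand for an effect only at larger amounts of compound and lower numbers for an effect already at smaller amounts), where compound 2 gives 100 mg/kg. Two companions share its core with a different five-membered ring: compound 1 `O=C(O)c1ccc(-c2cscn2)cc1O` gives 70 mg/kg, and compound 3 `O=C(O)c1ccc(-c2nccs2)cc1O` gives 110 mg/kg. Between them lies a 1.6-fold higher number from compound 1 to compound 3 (0.20 log units; within the scatter), a swap of the point at which the same ring is attached. Compound 2 thus stands second highest of the three, with both neighbours inside the usual scatter. Compound 4 `O=C(O)c1cc(-c2ccno2)ccc1O` differs from compound 2 by 1,2-oxazol-5-yl in place of 1,3-oxazol-2-yl on an aromatic carbon, again a rearrangement of an unchanged set of atoms. Among the compounds with values here, the only comparable step, from compound 1 to compound 3, stayed within scatter, so no step beyond scatter is expected here: compound 4 is estimated at 100 mg/kg, between 55 mg/kg and 180 mg/kg, an expected no change at the digits printed from compound 2 to compound 4 (within the scatter).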

Compound 4, dose for half-maximal effect: 110 mg/kg
Estimate against measurement, compound 4: 1.1-fold (0.04 log units) below, within the range that was stated.
By their numbers in this assay, from the lowest: compounds 1, 2, 3 and 4 (each within the scatter of the next).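

At the place para to a hydroxy group and meta to a carboxy group, 1,2-oxazol-5-yl in place of 1,3-oxazol-2-yl gives a 1.1-fold higher number from compound 2 to compound 4 (0.04 log units; within the scatter) in this assay. The earlier step concerned two thiazolyl groups, so this extends the same finding to a ring with oxygen: rearranging the atoms of the attached ring stays within the scatter. No measurement shown here offers an explanation for this result. The compounds shown leave open whether a ring is needed at this place at all, and whether an amine or a longer chain there would give a step beyond the scatter.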